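Two Pyridine Analogues and a Third Awaiting Measurement

This account rests on a few compounds, and the source may have more. Where it says the series, first, only, none or still open, it means among the compounds named here.

Measured so far:
compound 1, `COc1nc(-c2cc3ccccc3o2)cc(-c2ccc(Cl)cc2)c1C#N`: 286000 nM
compound 2, `CCOc1nc(-c2cc3ccccc3o2)cc(-c2ccc(Cl)cc2)c1C#N`: 221000 nM

Of the compounds shown here, two sharing one core have been tested in a functional assay on aorta (strain Wistar) for inhibition, with Thoracic aorta (Rattus norvegicus) as the target; on this read-out lower numbers stand for stronger inhibition and higher numbers for weaker inhibition. Compound 1 gives 286000 nM. Compound 2 differs from it only by methyl in place of hydrogen on a saturated chain carbon bound to an oxygen on an aromatic ring, and in this assay compound 2 gives 221000 nM. The step of a 1.3-fold lower number from compound 1 to compound 2 (0.11 log units; within the scatter) is within the scatter, so the two numbers cannot be told apart; compound 2 merely shows the lower of the two figures.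

Compound 3, `CCOc1nc(-c2cc3ccccc3o2)cc(-c2ccc(OC)cc2OC)c1C#N`, has not yet been measured. It differs from compound 2 by 2,4-dimethoxyphenyl in place of 4-chlorophenyl on an aromatic carbon. Within the data shown here, no measured step touches this position, since the only step on record, a 1.3-fold lower number from compound 1 to compound 2 (0.11 log units; within the scatter), concerns the ethoxy group and was itself within the scatter. There is therefore nothing to argue for a shift in either direction, and the expectation is a step of about a 1.1-fold higher number from compound 2 to compound 3 (0.05 log units; within the scatter), with a wide range. Compound 3 is expected to give roughly 250000 nM in this assay, estimated between 60000 nM and 1000000 nM.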

Compound 3, half-maximal inhibitory concentration: 488000 nM
Beside the measured number, compound 3's estimate is 2.0-fold (0.29 log units) below it; measured number inside the range.
By their numbers in this assay, from the lowest: compounds 2, 1 and 3 (each within the scatter of the next, the first and the last beyond it).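

In this assay, among these compounds, the aromatic carbon ortho to a cyano group and opposite the ring nitrogen is the first place where a change moves the read-out beyond the scatter: putting 2,4-dimethoxyphenyl in place of 4-chlorophenyl gives a 2.2-fold higher number from compound 2 to compound 3 (0.34 log units; beyond the scatter), a modest step towards weaker inhibition, whereas the earlier step on the ether chain, a 1.3-fold lower number from compound 1 to compound 2 (0.11 log units; within the scatter), stayed within it. This position therefore responds to substitution, at least for this pair, though the change has several parts: the chlorine leaves, two methoxy groups enter, and the count of hydrogen-bond acceptors on the group goes from 0 to 2 while the six-membered aromatic ring of carbon stays. Nothing available explains why the number moves in this direction.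

The compounds shown leave open whether the step comes from losing the chlorine or from gaining either methoxy group, since these changes arrive together. They also leave open how an amine or a carboxylic acid on the phenyl ring at this place would read, and whether the step would be the same with the methoxy group of compound 1 in place of the ethoxy group.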